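Fluoro for methoxy on a second sulfonate ester core

A few compounds are considered here, and "the series" means these few. Any claim that something is new, unique, unknown or untested is made for them only; others in the source may bear on it.

Measured compounds:
compound 1 `CCCN1CCN(c2ccc(S(=O)(=O)Oc3cccc(OC)c3)cc2)C1=O` — in a functional assay on HT-29 cells (Homo sapiens) for antiproliferative activity, read by sulforhodamine B assay, with a stated time of 48 h (a lower number here means a stronger inhibitor, a higher number a weaker inhibitor), compound 1 gives 25000 nM
compound 2 `CCCN1CCN(c2ccc(S(=O)(=O)Oc3cccc(F)c3)cc2)C1=O` — compound 2 gives 18000 nM
compound 3 `CCCCN1CCN(c2ccc(S(=O)(=O)Oc3cccc(OC)c3)cc2)C1=O` — compound 3 gives 13000 nM

Compound 2 carries the change fluoro in place of methoxy on an aromatic carbon relative to compound 1, and this gave a 1.4-fold lower number from compound 1 to compound 2 (0.14 log units; within the scatter). Compound 3 differs from compound 1 in its core by methyl in place of hydrogen on a saturated chain carbon, three bonds along the chain from an amide-type nitrogen in a ring, giving a 1.9-fold lower number from compound 1 to compound 3 (0.28 log units; within the scatter). The three values therefore sit close to one another, and none can be set apart from the others.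

Compound 4 `CCCCN1CCN(c2ccc(S(=O)(=O)Oc3cccc(F)c3)cc2)C1=O` has not yet been measured in this assay. It differs from compound 3 by fluoro in place of methoxy on an aromatic carbon, the same change seen from compound 1 to compound 2, made at the same place on the same kind of aromatic carbon but on the core of compound 3. Going by the values given here, the only guide is the earlier step; because that step was a 1.4-fold lower number from compound 1 to compound 2 (0.14 log units; within the scatter), compound 4 is expected to show a step of a 1.4-fold lower number from compound 3 to compound 4 (0.14 log units; within the scatter), small and within scatter. Compound 4 is thus estimated to give 9500 nM, with a range from 4500 nM to 20000 nM.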

Compound 4, half-maximal inhibitory concentration: 76000 nM
Estimate against measurement, compound 4: 8.0-fold (0.90 log units) below; measured number outside the range, above it.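

In this assay, fluoro in place of methoxy on an aromatic carbon did not carry over from one core to the other, giving a 5.8-fold higher number from compound 3 to compound 4 (0.77 log units; beyond the scatter), which does not match the earlier step: the same change on two cores in this assay, a 1.4-fold lower number (0.14 log units; within the scatter) from compound 1 to compound 2 and a 5.8-fold higher number (0.77 log units; beyond the scatter) from compound 3 to compound 4, 8.1-fold (0.91 log units) apart, beyond the scatter of two such steps. Methyl in place of hydrogen on the saturated chain carbon shows the same mismatch where fluoro is present, giving a 4.2-fold higher number from compound 2 to compound 4 (0.63 log units; beyond the scatter): the same change on two cores in this assay, a 1.9-fold lower number (0.28 log units; within the scatter) from compound 1 to compound 3 and a 4.2-fold higher number (0.63 log units; beyond the scatter) from compound 2 to compound 4, 8.1-fold (0.91 log units) apart, beyond the scatter of two such steps. Both comparisons rest on the same four compounds, so they form a single finding that the two changes do not add up here, and they show neither why this is so nor whether it would hold on any other core.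

On these data alone, it remains open whether a longer chain such as pentyl on the ring nitrogen would follow compound 4 or compound 2. As far as these compounds go, it is equally open whether chloro or a hydroxyl group in place of fluoro on the aromatic carbon would give a step like the one seen on the core of compound 3.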